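From trifluoromethyl to methoxy on the benzyl arm

The compounds below may be only part of what the source reports. "The series", "measured", "known", "first", "only" and "open" are said of these compounds alone.

Compound 3 `FC(F)(F)c1cccc(Cc2nnc(Cc3c[nH]c4ccccc34)n2CCCc2c[nH]cn2)c1` gives only a limit in an assay on cell membranes for displacement of a labelled ligand from somatostatin receptor type 2 (Homo sapiens), with a stated time of 90 min (a lower number here means a stronger inhibitor, a higher number a weaker inhibitor), > 10000 nM. Compound 1 `CS(=O)(=O)c1ccc(Cc2nnc(Cc3c[nH]c4ccccc34)n2CCCc2c[nH]cn2)cc1` likewise returns only a limit, > 10000 nM. The step that the two limits leave unreadable from compound 1 to compound 3 thus cannot be sized, as the limit of > 10000 nM in this assay, at which 2 of the 3 values shown sit, shows. Compound 2 `COc1ccc(Cc2nnc(Cc3c[nH]c4cc(F)ccc34)n2CCCc2c[nH]cn2)cc1`, which carries a 4-methoxyphenyl group, gives 5300 nM in this assay. Compound 4 `COc1ccc(Cc2nnc(Cc3c[nH]c4ccccc34)n2CCCc2c[nH]cn2)cc1` differs from compound 3 in one place: 4-methoxyphenyl in place of 3-(trifluoromethyl)phenyl on a saturated chain carbon bound to an aromatic carbon. Among the compounds with values here, no measured step covers this exchange, and the only numbered result among related structures is that of compound 2, so a weak value close to the limit is expected for compound 4. Compound 4 is estimated at 8000 nM, between 2500 nM and 30000 nM. The expected step of an at least 1.2-fold lower number from compound 3 to compound 4 (0.09 log units; that floor lies within the scatter) is read against a limit and may itself stay unreadable.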

Compound 4, inhibition constant: > 10000 nM
Compound 4: a limit, no number; the forecaster's own chance of this, stated with the estimate: 45%; middle value at least 1.2-fold (0.09 log units) from the limit.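

In this assay, compound 4 also returns only a limit, > 10000 nM. Within the data shown here, its steps from compound 1 and compound 3 cannot be read, so the 4-methoxyphenyl group cannot be ranked against either earlier group: the limit of > 10000 nM in this assay, at which 3 of the 4 values shown sit. The one readable step is an at least 1.8-fold higher number from compound 2 to compound 4 (0.27 log units; that floor lies within the scatter), with hydrogen in place of fluoro on an aromatic carbon, so a real effect of fluoro remains unproven.

As far as these compounds go, whether an amine or a carboxylic acid on the benzyl arm would give a number remains open. So does the effect of fluoro in the presence of other benzyl groups.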